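Working notes: from compound 2 to compound 3

The source may hold more compounds than are shown below. What is called first, only, known or untested is meant among the compounds shown, and "the series" means these compounds.

Measured in a functional assay on MDA-MB-231 cells (Homo sapiens) for antiproliferative activity, read by MTT assay, with a stated time of 24 h; on this read-out higher numbers stand for weaker inhibition and lower numbers for stronger inhibition:
- compound 1 `O=C1CC[C@@H](C(=O)N2CCN(c3nccc(Oc4cc(Cl)cc(Cl)c4)n3)CC2)N1`: > 50000 nM (a limit of the assay, not a number)
- compound 2 `COc1ccc(S(=O)(=O)N2CCN(c3nccc(Oc4cc(Cl)cc(Cl)c4)n3)CC2)cc1`: 46800 nM

Compound 1 gives only a limit in this assay, > 50000 nM. Within the data shown here, compound 2, at 46800 nM, holds the only number in the pair and lies close to the limit of > 50000 nM in this assay, at which 1 of the 2 values shown sits.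

Compound 3 `O=S(=O)(c1cccnc1)N1CCN(c2nccc(Oc3cc(Cl)cc(Cl)c3)n2)CC1` is the next to be read. Its change from compound 2 is pyridin-3-yl in place of 4-methoxyphenyl on a sulfonyl sulfur.

Among the measured compounds shown here, no measured step covers this change, so the expectation rests on compound 2 at 46800 nM. No shift beyond the usual scatter is expected in this assay, in either direction. The expected step of a 1.2-fold lower number from compound 2 to compound 3 (0.07 log units; within the scatter) is an estimate only. For compound 3 the expected value is 40000 nM, with an estimated range from 18000 nM to 50000 nM.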

Compound 3, half-maximal inhibitory concentration: 24800 nM
The estimate for compound 3 lay 1.6-fold (0.21 log units) above the measured number, within the range that was stated.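

In this assay, among these compounds, pyridin-3-yl in place of 4-methoxyphenyl on a sulfonyl sulfur gives a 1.9-fold lower number from compound 2 to compound 3 (0.28 log units; within the scatter), the first measured step at this position, and it does not separate the two groups. Exchanging (5-oxopyrrolidin-2-yl)carbonyl for (pyridin-3-yl)sulfonyl on an amine nitrogen in a ring gives an at least 2.0-fold lower number from compound 1 to compound 3 (0.30 log units; that floor lies within the scatter), so this step too shows no change beyond the scatter. Compound 1 holds a limit of the assay, which makes that step a floor and leaves its true size unknown: the limit of > 50000 nM in this assay, at which 1 of the 3 values shown sits.

From the compounds shown here alone, whether any group on the sulfonyl sulfur can move the number beyond the scatter remains open. A butyl chain, or a phenyl ring carrying a carboxylic acid or an amine, would test that question at this position.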